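A few compounds are considered here, and "the series" means these few. Any claim that something is new, unique, unknown or untested is made for them only; others in the source may bear on it.

Working notes on the series. Compound 1 `CC(C)C1(C(C)C)NC(=O)N(CN2CCN(c3cccc(Cl)c3)CC2)C1=O` is the reference point; in a functional assay on the whole organism (strain CD1) with Mus musculus as the target, in the maximal electroshock model, with a stated time of 4 h (on this read-out higher numbers stand for an effect only at larger amounts of compound and lower numbers for an effect already at smaller amounts), compound 1 gives 100 mg/kg. Compound 2 `CC(C)C1(C(C)C)NC(=O)N(CN2CCN(c3ccccc3F)CC2)C1=O` carries 2-fluorophenyl in place of 3-chlorophenyl on an amine nitrogen in a ring, and in this assay compound 2 gives 100 mg/kg. Among the measured compounds shown here, the step of no change at the digits printed from compound 1 to compound 2 (within the scatter) lies within the scatter, so compound 2 stands level with compound 1 at the digits recorded, and compound 1 is its only measured neighbour.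

Compound 3 `CC(C)C1(C(C)C)NC(=O)N(CN2CCN(c3ccccc3)CC2)C1=O` is not yet measured. Relative to compound 2 the change is hydrogen in place of fluoro on an aromatic carbon; cut one bond further out, the aryl group reads 2-fluorophenyl to phenyl. For the measured compounds named here, the only measured step that bears on this is the exchange of one aryl group for another, no change at the digits printed from compound 1 to compound 2 (within the scatter), which moved the read-out by nothing beyond the scatter. On that basis the expected step of no change at the digits printed from compound 2 to compound 3 (within the scatter) is none beyond the scatter, in no particular direction. The estimate for compound 3 in this assay is therefore 100 mg/kg, with an expected range from 50 mg/kg to 300 mg/kg.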

Compound 3, minimum effective dose: 300 mg/kg
Beside the measured number, compound 3's estimate is 3.0-fold (0.48 log units) below it; measured number inside the range.
By their numbers in this assay, from the lowest: compounds 1 and 2 (each within the scatter of the next); then compound 3.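

In this assay the loss of the fluoro group from the aromatic carbon ortho to a large group gives a 3.0-fold higher number from compound 2 to compound 3 (0.48 log units; beyond the scatter) and so marks the first movement beyond the scatter in this series, with compound 3 showing an effect only at a larger amount of compound. Hydrogen in place of chloro gives the same result, a 3.0-fold higher number from compound 1 to compound 3 (0.48 log units; beyond the scatter) and thus the bare phenyl group stands apart from both halogen-bearing aryl groups. The earlier exchange of 3-chlorophenyl for 2-fluorophenyl could not show this, since it left the read-out level; the aryl group is therefore not indifferent here, and within these three compounds each halogen-bearing aryl group gives a lower number than phenyl.

The compounds shown do not separate the identity of the halogen from its place on the ring, as 2-chlorophenyl and 3-fluorophenyl are not among them. On these data alone, whether a methyl or methoxy group on the same aromatic carbon would read like the halogens or like hydrogen also stays open. Nothing available here offers an explanation for the step from fluoro to hydrogen.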